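Replacing ethylamino with methyl on an aromatic carbon

A few compounds are considered here, and "the series" means these few. Any claim that something is new, unique, unknown or untested is made for them only; others in the source may bear on it.

Measured in a functional assay on the whole organism with Rattus norvegicus as the target; a lower number here means that less compound is needed, a higher number that more compound is needed for the effect:
Compound 1 `CCOC(=O)C(=O)Nc1cc(N(C)C)ccc1C#N`: 1.9 mg/kg
Compound 2 `CCNc1cccc(NC(=O)C(=O)OCC)c1C#N`: 0.03 mg/kg

Of these two numbers, compound 2 holds the lower one (0.03 mg/kg), and its gap to compound 1 (1.9 mg/kg) lies beyond the usual scatter. Less of compound 2 is therefore needed for the effect in this assay.

Compound 3 `CCOC(=O)C(=O)Nc1cccc(C)c1C#N` has not yet been measured. Compared with compound 2, it carries methyl in place of ethylamino on an aromatic carbon. That carbon stands ortho to a cyano group. Among the compounds with values here, no measured pair shows this change on its own, so the data give no direct size for it.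

Compound 2 sits at the low end of the two numbers (0.03 mg/kg), so a higher number is the likelier outcome for the new compound. The expected change is moderate but beyond the scatter, and the estimated step is a 10-fold higher number from compound 2 to compound 3 (1.00 log units; beyond the scatter). For compound 3 the estimated value is 0.3 mg/kg, with an expected range from 0.05 mg/kg to 2 mg/kg.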

Compound 3, dose for half-maximal effect: 5.3 mg/kg
Compound 3: the middle estimate sits 18-fold (1.25 log units) below what was measured; measured number outside the range, above it.
By their numbers in this assay, from the lowest: compound 2; then compound 1; then compound 3.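

In this assay, exchanging ethylamino for methyl on the aromatic carbon ortho to a cyano group gives a 180-fold higher number from compound 2 to compound 3 (2.25 log units; beyond the scatter), a large change from one substitution. The earlier compounds shown here differ in more than one place, so their gap could not be tied to this carbon; this pair shows that the group on this carbon alone can strongly change how much compound is needed, with the lower number belonging to the ethylamino compound. The two groups differ in heavy atoms and in hydrogen-bond donors and acceptors, but no measurement here separates these differences or accounts for the size of the step.

On these data alone, what remains open is whether the low number of compound 2 depends on the nitrogen, on the ethyl chain or on both together: a plain amino group, a methylamino group, an ethyl group and a longer chain such as propylamino on the same carbon would each divide the change. As far as these compounds go, it is also open whether the step would keep its size with other groups elsewhere on the shared core.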